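Swapping the Aryl Group on the Sulfonamide Nitrogen

This account rests on a few compounds, and the source may have more. Where it says the series, first, only, none or still open, it means among the compounds named here.

- Compound 1 `O=C1NCCN1c1ccc(S(=O)(=O)Nc2ccc(F)cc2)cc1`: 230 nM
- Compound 2 `Cc1cccc(NS(=O)(=O)c2ccc(N3CCNC3=O)cc2)c1C`: 110 nM

Both values come from a functional assay on M21 cells (Homo sapiens) for antiproliferative activity, read by sulforhodamine B assay, with a stated time of 48 h; a lower number here means a stronger inhibitor, a higher number a weaker inhibitor. Among the compounds with values here, of the two compounds measured so far, compound 2 has the lower number, at 110 nM.

The next compound to be tested is compound 3 `COc1ccccc1NS(=O)(=O)c1ccc(N2CCNC2=O)cc1`. It keeps the shared core of compound 2, but 2-methoxyphenyl takes the place of 2,3-dimethylphenyl on a sulfonamide nitrogen: 2-methoxyphenyl in place of 2,3-dimethylphenyl on a sulfonamide nitrogen.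

Within the data shown here, only one measured step bears on this change, because it alters the same place: a 2.1-fold lower number from compound 1 to compound 2 (0.32 log units; beyond the scatter). That step is modest, and a single step is thin evidence. Among the measured compounds shown here, no measured compound carries the 2-methoxyphenyl group, so its effect in this assay remains open. For the measured compounds named here, a modest step is expected again, with a somewhat higher number more likely than a lower one, since compound 2 holds the lower of only two values.

The expected change is a 1.5-fold higher number from compound 2 to compound 3 (0.19 log units; within the scatter). For compound 3, the estimated value is 170 nM, with an expected range of 60 nM to 500 nM.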

Compound 3, half-maximal inhibitory concentration: 300 nM
Compound 3: middle estimate off by 1.8-fold (0.25 log units), on the low side; the measured number falls inside the stated range.
By their numbers in this assay, from the lowest: compound 2; then compounds 1 and 3 (each within the scatter of the next).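

Placing 2-methoxyphenyl on the sulfonamide nitrogen gives a 2.7-fold higher number from compound 2 to compound 3 (0.44 log units; beyond the scatter) in this assay, so this position does not respond only in the favourable direction seen with the earlier swap. Replacing 4-fluorophenyl with the same group gives a 1.3-fold higher number from compound 1 to compound 3 (0.12 log units; within the scatter), which leaves compound 1 and compound 3 indistinguishable, while compound 2, whose steps to both are beyond the scatter, is the strongest of the three. The 2,3-dimethylphenyl and 2-methoxyphenyl groups each have 8 heavy atoms and one six-membered aromatic ring, differing in that the entering group contains 1 oxygen and 1 hydrogen-bond acceptor, yet no measurement here connects either feature to the difference in activity.

Within the data shown here, with only three aryl groups compared, it remains open whether the advantage of compound 2 depends on having both methyl groups or whether one would be enough. It is also unknown how this position would respond to a longer chain such as ethoxy, to an amine, or to a carboxylic acid on the aromatic ring.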